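Swapping trifluoromethoxy for tert-butyl on the aromatic ring

A few compounds are considered here, and "the series" means these few. Any claim that something is new, unique, unknown or untested is made for them only; others in the source may bear on it.

In a functional assay on the whole organism with Rattus norvegicus as the target (a lower number here means that less compound is needed, a higher number that more compound is needed for the effect), compound 1 (`N=c1sc2cc(OC(F)(F)F)ccc2n1Cc1ccccc1`) gives > 10 mg/kg, which is a limit of the assay and not a number. Compound 2 (`N=c1sc2cc(OC(F)(F)F)ccc2n1CCO`) gives 8 mg/kg, and compound 3 (`CN(C)CCn1c(=N)sc2cc(OC(F)(F)F)ccc21`) has the lowest number, 2.3 mg/kg. Compound 4 (`CN(C)CCn1c(=N)sc2cc(C(C)(C)C)ccc21`) keeps the chain of compound 3 but has tert-butyl in place of trifluoromethoxy on an aromatic carbon. The measured steps, a 3.5-fold lower number from compound 2 to compound 3 (0.54 log units; beyond the scatter) and an at least 4.3-fold lower number from compound 1 to compound 3 (0.63 log units; beyond the scatter), both changed the chain on the aromatic nitrogen. Neither tests this aromatic carbon, so they set no size for the new step. The expected result is a 1.7-fold higher number from compound 3 to compound 4 (0.24 log units; within the scatter), a slight rise that stays within the scatter. For compound 4 the estimate is 4 mg/kg, with an expected range of 1.5 mg/kg to 12 mg/kg.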

Compound 4, dose for half-maximal effect: > 10 mg/kg
Compound 4: a limit, no number; the forecaster's own chance of this, stated with the estimate: 20%; middle value at least 2.5-fold (0.39 log units) away from the limit.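

Among these compounds, with the chain on the aromatic nitrogen held fixed, tert-butyl in place of trifluoromethoxy gives an at least 4.3-fold higher number from compound 3 to compound 4 (0.63 log units; beyond the scatter) in this assay and so shows that the group on this aromatic carbon, untouched by the earlier steps, also affects the dose needed. From the compounds shown here alone, the value of compound 4 is a limit and not a number, so this step is only a floor and its full size stays unknown: the limit of > 10 mg/kg in this assay, at which 2 of the 4 values shown sit. Open, going by these compounds, is whether a smaller group on this carbon, such as chlorine or methoxy, would serve as well as trifluoromethoxy. Also open, on these data alone, is how tert-butyl would behave with a longer amine chain on the aromatic nitrogen.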